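Side-chain amine variation in the series

The compounds below may be only part of what the source reports. "The series", "measured", "known", "first", "only" and "open" are said of these compounds alone.

Measured so far:
compound 1 `Cc1cc(-c2ccccc2)nnc1NCCCN`: 0.1 mg/kg
compound 2 `CNCCNc1nnc(-c2ccccc2)cc1C`: 2 mg/kg

Within the data shown here, in a functional assay on the whole organism with Mus musculus as the target (a lower number here means that less compound is needed, a higher number that more compound is needed for the effect), compound 2 stands at the highest of the two numbers; the one measured step, a 20-fold higher number from compound 1 to compound 2 (1.30 log units; beyond the scatter), is large and beyond the scatter. Compound 3 `CCCN(CCC)CCNc1nnc(-c2ccccc2)cc1C` differs from compound 2 by dipropylamino in place of methylamino on a saturated chain carbon, two bonds along the chain from a nitrogen on an aromatic ring. Among the measured compounds shown here, no measured step covers this change; the only step known concerns another change at the same place. Given that step, a further move upward in this assay is expected, of moderate size: a 2.5-fold higher number from compound 2 to compound 3 (0.40 log units; beyond the scatter). Compound 3 is therefore estimated at 5 mg/kg, with a range from 1 mg/kg to 25 mg/kg.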

Compound 3, minimum effective dose: 2 mg/kg
Compound 3: the middle estimate sits 2.5-fold (0.40 log units) above what was measured, within the range that was stated.
By their numbers in this assay, from the lowest: compound 1; then compounds 2 and 3 (each within the scatter of the next).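

At this saturated chain carbon, two bonds along the chain from a nitrogen on an aromatic ring, dipropylamino in place of methylamino gives no change at the digits printed from compound 2 to compound 3 (within the scatter) in this assay, so adding carbons and dropping the hydrogen-bond donor leaves this read-out unmoved. Dipropylamino in place of aminomethyl gives a 20-fold higher number from compound 1 to compound 3 (1.30 log units; beyond the scatter), so two different amines now share the large gap to compound 1. No available evidence bears on this result.

From the compounds shown here alone, whether that gap follows from chain length or from substitution on the nitrogen stays open. A piperidine ring or a dipropylamino group on the longer chain of compound 1 would separate these.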